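A few compounds are considered here, and "the series" means these few. Any claim that something is new, unique, unknown or untested is made for them only; others in the source may bear on it.

The study measures two compounds in a functional assay for agonist activity at G protein-coupled receptor 88 (Homo sapiens), read by HTRF and cAMP accumulation; on this read-out higher numbers stand for an effect only at larger amounts of compound and lower numbers for an effect already at smaller amounts. Compound 1, `CC(C)CCCN(C(=O)[C@@H]1C[C@H]1c1ccccc1)c1ccc(-c2ccccc2)cc1`, is reported only as a limit of the assay: in this assay compound 1 gives > 100 nM, and (the limit of > 100 nM in this assay, at which 1 of the 2 values shown sits). Going by the values given here, compound 2, `CCCc1ccc(-c2ccc(N(C[C@@H](N)[C@@H](C)CC)C(=O)[C@@H]3C[C@H]3c3ccccc3)cc2)cc1`, is the one compound with an actual number: in this assay compound 2 gives 61 nM. Since the other entry is a limit, nothing can be said about the order of compound 1 and compound 2.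

Compound 3, `CC[C@H](C)[C@H](N)CN(C(=O)[C@@H]1C[C@H]1c1ccccc1)c1ccc(-c2ccc(NS(C)(=O)=O)cc2)cc1`, is not yet measured. It differs from compound 2 in one place, (methanesulfonamido in place of propyl on an aromatic carbon), on an aromatic carbon of a six-membered aromatic ring of carbon only, para to a large group. Among the compounds with values here, no measured pair shows the effect of such an exchange here, so the expectation rests on compound 2 alone. The step of a 2.5-fold higher number from compound 2 to compound 3 (0.39 log units; beyond the scatter) is expected to be a modest loss, possibly beyond the scatter. For compound 3 the estimate in this assay is 150 nM, within 40 nM to 600 nM.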

Compound 3, half-maximal effective concentration: 1200 nM
Estimate against measurement, compound 3: 8.0-fold (0.90 log units) below, and the stated range ends below it.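

The exchange of propyl for methanesulfonamido, on an aromatic carbon para to a large group, comes with a 20-fold higher number from compound 2 to compound 3 (1.29 log units; beyond the scatter) in this assay. With a single number on compound 2, nothing could be said about how much this place responds to the group it carries; this pair shows that the response can be large and that a change here can move the value beyond the scatter. Nothing measured here accounts for the size of this step.

The compounds shown leave open whether a longer chain such as butyl, a methoxy group or an acetamido group at this place would stay close to compound 2 or fall closer to compound 3. They also leave open whether the sulfonyl group or the sulfonamide hydrogen goes with the loss, as this one pair changes both together.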